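Acyl variation on the shared core and cytotoxicity

The compounds below may be only part of what the source reports. "The series", "measured", "known", "first", "only" and "open" are said of these compounds alone.

Measured so far:
compound 1, `Cc1cncc(C(=O)n2c(-c3cn(-c4ccccc4)nc3-c3ccc(F)cc3)nc3ccccc32)c1`: 119000 nM
compound 2, `Cc1ccc(-c2nn(-c3ccccc3)cc2-c2nc3ccccc3n2C(=O)c2cncc(C)c2)cc1`: 155000 nM
compound 3, `Cc1ccccc1C(=O)n1c(-c2cn(-c3ccccc3)nc2-c2ccc(C(F)(F)F)cc2)nc2ccccc21`: 179000 nM

All three numbers come from an ADME assay on HEK-293T cells (Homo sapiens) for cytotoxicity, read by MTT assay, with a stated time of 24 h; a lower number here means that less compound is tolerated, a higher number that more compound is tolerated. Compound 3 holds the highest of the three numbers, but its gap to compound 2 and its gap to compound 1 are both within the scatter, so no order among the three can be read. For the measured compounds named here, the one step between measured compounds that differ in a single place, a 1.3-fold higher number from compound 1 to compound 2 (0.11 log units; within the scatter), is also within the scatter.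

Compound 4, `Cc1cncc(C(=O)n2c(-c3cn(-c4ccccc4)nc3-c3ccc(C(F)(F)F)cc3)nc3ccccc32)c1`, is not yet measured in this assay. It differs from compound 3 by 5-methylpyridin-3-yl in place of 2-methylphenyl on a carbonyl carbon. Going by the values given here, no measured pair shows this particular change on its own, so no step bears on it directly. What the numbers do show is that compound 1 and compound 2, which already carry the (5-methylpyridin-3-yl)carbonyl, sit within the scatter of compound 3, which carries the (2-methylphenyl)carbonyl. On that basis the step of a 1.2-fold lower number from compound 3 to compound 4 (0.09 log units; within the scatter) is expected to stay within the scatter, with no direction beyond it. Compound 4 is therefore estimated at 145000 nM in this assay, within a range of 75000 nM to 280000 nM.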

Compound 4, half-maximal cytotoxic concentration: 123000 nM
Beside the measured number, compound 4's estimate is 1.2-fold (0.07 log units) above it; the measured number falls inside the stated range.
By their numbers in this assay, from the lowest: compounds 1, 4, 2 and 3 (each within the scatter of the next).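

In this assay, the change at the carbonyl carbon can now be read on its own: 5-methylpyridin-3-yl in place of 2-methylphenyl, which adds one ring nitrogen and one hydrogen-bond acceptor at equal heavy-atom count, gives a step within the scatter (a 1.5-fold lower number from compound 3 to compound 4 (0.16 log units; within the scatter)), so this pair shows no separation between the two groups at this position. With the (5-methylpyridin-3-yl)carbonyl held constant, the substituent on the aromatic carbon can also be compared more fully: trifluoromethyl in place of methyl (a 1.3-fold lower number from compound 2 to compound 4 (0.10 log units; within the scatter)) and trifluoromethyl in place of fluoro (a 1.0-fold higher number from compound 1 to compound 4 (0.01 log units; within the scatter)) both stay within the scatter, so trifluoromethyl, methyl and fluoro cannot be told apart in this setting. No supporting measurement is available to explain any of these numbers.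

The compounds shown leave open whether a carbonyl substituent of another kind, such as a longer alkyl chain or a ring carrying an amine or a carboxylic acid, would stay in the same range. They also leave open whether the fluoro and methyl groups on the aromatic carbon would behave the same way alongside the (2-methylphenyl)carbonyl.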